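The source may hold more compounds than are shown below. What is called first, only, known or untested is meant among the compounds shown, and "the series" means these compounds.

Measured compounds and their numbers in a functional assay on SGC-7901 cells (Homo sapiens) for antiproliferative activity, read by MTT assay, with a stated time of 72 h; a lower number here means a stronger inhibitor, a higher number a weaker inhibitor:
compound 1, `CCOC(=O)c1cc(-c2ccc(OC)c([N+](=O)[O-])c2)c(-c2cc(OC)c(OC)c(OC)c2)s1`, gives 19400 nM
compound 2, `CCOC(=O)c1cc(-c2ccc(OC)c(O)c2)c(-c2cc(OC)c(OC)c(OC)c2)s1`, gives 20000 nM
compound 3, `COc1ccc(-c2cc(C(=O)O)sc2-c2cc(OC)c(OC)c(OC)c2)cc1[N+](=O)[O-]`, gives 21600 nM

Compound 3 stands together with the other two: the step of a 1.1-fold higher number from compound 1 to compound 3 (0.05 log units; within the scatter) is within the scatter, and the value of compound 3 and that of compound 2 also lie within the scatter of each other, so no order among the three can be read from these numbers.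

Compound 4, `COc1ccc(-c2cc(C(=O)O)sc2-c2cc(OC)c(OC)c(OC)c2)cc1O`, has not yet been measured. Its relation to compound 3 is hydroxy in place of nitro on an aromatic carbon

For the measured compounds named here, the one measured step that bears directly on this change is a 1.0-fold higher number from compound 1 to compound 2 (0.01 log units; within the scatter), the same swap of hydroxy for nitro carried out on the ethyl ester instead of the acid. That step was within the scatter. The step of a 1.1-fold higher number from compound 1 to compound 3 (0.05 log units; within the scatter) shows that the acid and the ester also sit within the scatter of each other, so there is no sign in these three compounds that the acid would respond to the swap differently from the ester.

The expectation for compound 4 is therefore a step of a 1.0-fold higher number from compound 3 to compound 4 (0.01 log units; within the scatter), that is, no change beyond the scatter. Compound 4 is estimated at 22000 nM, with a range from 11000 nM to 44000 nM.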

Compound 4, half-maximal inhibitory concentration: 17500 nM
Compound 4: the middle estimate sits 1.3-fold (0.10 log units) above what was measured, within the range that was stated.
By their numbers in this assay, from the lowest: compounds 4, 1, 2 and 3 (each within the scatter of the next).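

In this assay, the swap of hydroxy for nitro, on an aromatic carbon ortho to a methoxy group, can now be read on the acid as well as on the ethyl ester, and on the acid it gives a 1.2-fold lower number from compound 3 to compound 4 (0.09 log units; within the scatter). The swap thus leaves the number within the scatter on both cores, and the two readings agree: the same change on two cores in this assay, a 1.0-fold higher number (0.01 log units; within the scatter) from compound 1 to compound 2 and a 1.2-fold lower number (0.09 log units; within the scatter) from compound 3 to compound 4, 1.3-fold (0.10 log units) apart, within the scatter of two such steps

The change from ethyl ester to acid, so far read only with nitro in place, can now also be read with hydroxy in place, as a 1.1-fold lower number from compound 2 to compound 4 (0.06 log units; within the scatter), and it too stays within the scatter on both cores: the same change on two cores in this assay, a 1.1-fold higher number (0.05 log units; within the scatter) from compound 1 to compound 3 and a 1.1-fold lower number (0.06 log units; within the scatter) from compound 2 to compound 4, 1.3-fold (0.10 log units) apart, within the scatter of two such steps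

Nitro and hydroxy are the only two groups shown at this position, so it remains open whether another group there, such as an amine or a longer alkoxy chain, would move the number beyond the scatter. The ester and the acid are likewise the only two forms shown at the other position, and an amide or a nitrile there remains an open question.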